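This account rests on a few compounds, and the source may have more. Where it says the series, first, only, none or still open, it means among the compounds named here.

Compound 1 `CC(C)(C)c1cc(NC(=O)Nc2ccc(-c3cn4cc(Cl)ccc4n3)cc2)no1` and compound 3 `CC(C)(C)c1cc(NC(=O)Nc2ccc(-c3cn4c(Cl)cccc4n3)cc2)no1` are built from the same atoms joined differently; how their two cores differ is not broken down here. In a functional assay on MV4-11 cells (Homo sapiens) for cytotoxicity, read by MTT assay, with a stated time of 72 h (a higher number here means a weaker inhibitor, a lower number a stronger inhibitor), compound 1 gives 24.8 nM, and compound 3 gives 56.1 nM, the highest number of the three. Compound 2 `Cc1ccc2nc(-c3ccc(NC(=O)Nc4cc(C(C)(C)C)on4)cc3)cn2c1` differs from compound 1 by methyl in place of chloro on an aromatic carbon, and in this assay compound 2 gives 4.08 nM, a step of a 6.1-fold lower number from compound 1 to compound 2 (0.78 log units; beyond the scatter).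

Compound 4 `Cc1cccc2nc(-c3ccc(NC(=O)Nc4cc(C(C)(C)C)on4)cc3)cn12` is not yet measured. It differs from compound 3 by methyl in place of chloro on an aromatic carbon. Within the data shown here, this is the same kind of change as the one from compound 1 to compound 2, not the same one: there the methyl sat two atoms from the ring nitrogen, meta to a fused ring and para to a fused ring, whereas here it sits next to the ring nitrogen, ortho to a fused ring and meta to a fused ring. Resting on the step of a 6.1-fold lower number from compound 1 to compound 2 (0.78 log units; beyond the scatter), but tempered by the changed surroundings, compound 4 is expected to give a step of a 3.7-fold lower number from compound 3 to compound 4 (0.57 log units; beyond the scatter) in this assay. The estimate for compound 4 is 15 nM, between 5 nM and 45 nM.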

Compound 4, half-maximal inhibitory concentration: 20.2 nM
Compound 4: middle estimate off by 1.3-fold (0.13 log units), on the low side, within the range that was stated.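

In this assay, methyl in place of chloro lowers the number on both cores, here with a 2.8-fold lower number from compound 3 to compound 4 (0.44 log units; beyond the scatter), so the direction of this change carried over from one core to the other: the same change on two cores in this assay, a 6.1-fold lower number (0.78 log units; beyond the scatter) from compound 1 to compound 2 and a 2.8-fold lower number (0.44 log units; beyond the scatter) from compound 3 to compound 4, 2.2-fold (0.34 log units) apart, within the scatter of two such steps. On these data the two steps cannot be told apart in size, so no difference can be assigned to moving the change to the carbon next to the ring nitrogen. The comparison rests on one pair per core in a single assay, and it shows neither why the number falls nor that the change would behave alike on any further core or at any other place on the ring.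

The compounds shown carry only chloro or methyl at these two places, so it remains open how plain hydrogen, a methoxy group, an amine or a longer chain such as propyl would compare there. Also open, on these data alone, is whether methyl would keep its lower number against chloro in a different cell line.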